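The source may report more compounds than this note shows. Statements on the series, on what has been measured and on what is new or still open speak of the compounds shown alone.

In an ADME assay on microsomes from liver (Homo sapiens) for metabolic stability, read by LC-MS, with a stated time of 10 min, tested at 0.5 uM (on this read-out lower numbers stand for a less stable compound and higher numbers for a more stable compound), compound 1 (`c1ccc2c(c1)CN[C@@H](CN(CCCN1CCNCC1)[C@H]1CCCc3cccnc31)C2`) gives 100% and stands highest of the three measured compounds. Compound 2 (`NC(=O)N1CCN(CCCN(C[C@H]2Cc3ccccc3CN2)[C@H]2CCCc3cccnc32)CC1`) gives 79% and compound 3 (`c1ccc2c(c1)CN[C@@H](CN(CCCN1CCN(C3CC3)CC1)[C@H]1CCCc3cccnc31)C2`) gives 21% on the same scale. Carbamoyl in place of hydrogen on an amine nitrogen in a ring gives a number 21 percentage points lower from compound 1 to compound 2 (beyond the scatter) and cyclopropyl on that nitrogen gives a number 79 percentage points lower from compound 1 to compound 3 (beyond the scatter) as the larger move. Compound 4 (`c1cnc2c(c1)CCC[C@@H]2N(CCCN1CCNCC1)Cc1nc2ccccc2s1`) keeps that hydrogen and differs elsewhere: 1,3-benzothiazol-2-yl in place of 1,2,3,4-tetrahydroisoquinolin-3-yl on a saturated chain carbon bound to an amine nitrogen with 1,3-benzothiazol-2-yl in place of 1,2,3,4-tetrahydroisoquinolin-3-yl on a saturated chain carbon bound to an amine nitrogen. Neither measured step touches this place, so they show only how far numbers among these compounds can move. With compound 1 at 100% as the starting point, a lower number of modest to large size is expected for compound 4 in this assay here. The expected change is a number 40 percentage points lower from compound 1 to compound 4 (beyond the scatter) by this estimate. Compound 4 is estimated at 60% within an expected range from 25% to 95% for now.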

Compound 4, percent of the compound remaining: 50%
Compound 4: middle estimate off by 10 percentage points, on the high side; the range from low to high includes it.
By their numbers in this assay, from the lowest: compound 3; then compound 4; then compound 2; then compound 1.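

In this assay, the place on a saturated chain carbon bound to an amine nitrogen now has a step of its own: 1,3-benzothiazol-2-yl in place of 1,2,3,4-tetrahydroisoquinolin-3-yl gives a number 50 percentage points lower from compound 1 to compound 4 (beyond the scatter). Going by these compounds alone, the earlier steps changed only the group on an amine nitrogen in a ring, so this is the first sign that the read-out also responds at this second place, with that hydrogen kept. Nothing available explains the lower number.

The compounds leave open which part of the exchange goes with the lower number: the hydrogen-bond donor and defined stereocentre that leave, or the sulfur that enters. They also leave open where a phenyl group at this place would stand, and whether cyclopropyl on the amine nitrogen in a ring would act the same with 1,3-benzothiazol-2-yl present.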